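Adding a Second Chloro to the Purine-Like Core

The source may hold more compounds than are shown below. What is called first, only, known or untested is meant among the compounds shown, and "the series" means these compounds.

Compound 1 `ClCc1ccc(Cn2cnc3c(Cl)ncnc32)cc1` has no result in a functional assay on SNB-75 cells (Homo sapiens) for cytotoxicity, read by sulforhodamine B assay, with a stated time of 48 h; a higher number here means a weaker inhibitor of growth, a lower number a stronger inhibitor of growth: for compound 1 the entry in this assay reads "not determined" (no result reported). Among the compounds with values here, its close relative compound 2 `ClCc1cccc(Cn2cnc3c(Cl)ncnc32)c1` gives 4570 nM in this assay, and that single number is the only measured guide here. Compound 3 `ClCc1ccc(Cn2cnc3c(Cl)nc(Cl)nc32)cc1` differs from compound 1 by chloro in place of hydrogen on an aromatic carbon. Within the data shown here, no measured step of this kind is available, so the size and direction of the change cannot be read from earlier data; a shift no larger than the usual scatter seems as likely as any other. Compound 3 is expected to give roughly 4000 nM, most plausibly between 1000 nM and 16000 nM.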

Compound 3, concentration for total growth inhibition: 9330 nM
Compound 3: middle estimate off by 2.3-fold (0.37 log units), on the low side, and the stated range covers the measured number.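

The step from compound 1 to compound 3 cannot be read in this assay. The compounds shown leave open what adding the chloro does to growth inhibition. Nothing shown offers an explanation for the value of compound 3.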